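Compound 2 to compound 4: adding octylcarbonyl

The source may hold more compounds than are shown below. What is called first, only, known or untested is meant among the compounds shown, and "the series" means these compounds.

Of the compounds shown here, three have been measured in an ADME assay on microsomes from liver (Mus musculus) for metabolic stability, read by LC-MS, using NADPH, tested at 1 uM; a higher number here means that the compound lasts longer, a lower number that the compound disappears faster. Compound 1 `CCC(=O)NC/C=C\CN(C)C[C@H]1O[C@@H](n2cnc3c(N)ncnc32)[C@H](OC(C)=O)[C@@H]1OC(C)=O` gives 0.0767 h. Compound 2 `CN(C/C=C\CN)C[C@H]1O[C@@H](n2cnc3c(N)ncnc32)[C@@H]2OC(C)(C)O[C@@H]21` gives > 1.5 h, which is a limit of the assay and not a number. Compound 3 `Cc1nc2c(N)ncnc2n1[C@@H]1O[C@H](CN(C/C=C\CN)C2CC2)[C@H]2OC(C)(C)O[C@H]21` gives > 1.5 h, which is likewise a limit. Compound 2 therefore stands at the limit of > 1.5 h in this assay, at which 2 of the 3 values shown sit, so no exact half-life is available as a starting point.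

Compound 4 `CCCCCCCCC(=O)Nc1ncnc2c1ncn2[C@@H]1O[C@H](CN(C)C/C=C\CN)[C@H]2OC(C)(C)O[C@H]21` carries octylcarbonyl in place of hydrogen on a nitrogen on an aromatic ring, a change counted as octylcarbonyl in place of hydrogen on a nitrogen on an aromatic ring. Among the measured compounds shown here, no measured pair in this assay shows the size of this change. A fall in half-life beyond the scatter is expected, although its size is uncertain and a result at the limit remains possible. The only numerical guide is compound 1 at 0.0767 h, which shows that a short half-life occurs among these compounds. The expected change is an at least 3.0-fold lower number from compound 2 to compound 4 (0.47 log units; beyond the scatter). For compound 4 the estimated half-life is 0.5 h, with an expected range of 0.12 h to 1.5 h.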

Compound 4, half-life: 0.1 h
The estimate for compound 4 lay 5.0-fold (0.70 log units) above the measured number; measured number outside the range, below it.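

In this assay compound 2 gives > 1.5 h, a limit of the assay and not a number. The amino position, until now unchanged among the compounds shown, responds strongly: octylcarbonyl in place of hydrogen on this nitrogen gives an at least 15-fold lower number from compound 2 to compound 4 (1.17 log units; beyond the scatter), the first readable step in the series, and a large one. Its full size stays undetermined because the step starts from a limit: the limit of > 1.5 h in this assay, at which 2 of the 4 values shown sit.

Open, on these data alone, is whether the fall follows from the carbonyl on this nitrogen or from the length of the chain; a shorter chain such as acetyl in the same place would separate the two. Also open, as far as these compounds go, is which part of compound 4 is lost in the incubation, as the half-life alone does not identify the site of loss.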